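This account rests on a few compounds, and the source may have more. Where it says the series, first, only, none or still open, it means among the compounds named here.

Three compounds have so far been measured in a functional assay on SH-SY5Y cells (Homo sapiens) for cytotoxicity, read by MTT assay, with a stated time of 48 h, tested at 10 uM; on this read-out lower numbers stand for a stronger effect and higher numbers for a weaker effect at the one concentration tested:

Compound 1, `O=C(CCCCCCCCc1cn(-c2cnc3ccccc3c2)nn1)NCc1cccnc1`, gives 29%.
Compound 2, `O=C(CCCCCCCc1cn(-c2ccccc2-c2ccccc2)nn1)Nc1ccncc1`, gives 32%.
Compound 3, `O=C(CCCCCCCc1cn(-c2ccccc2CO)nn1)NCc1cccnc1`, gives 96%.

Among these three numbers compound 2 stands second highest. Its nearest neighbour is compound 1, whose number lies within the usual scatter of it, so the two cannot be told apart. Compound 3 lies furthest away, with a much higher number, beyond the scatter, meaning a weaker effect in this assay.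

The unmeasured compound 4, `O=C(CCCCCCCc1cn(-c2ccccc2-c2ccccc2)nn1)Nc1cccnc1`, is built from the same atoms as compound 2, joined differently. The difference is pyridin-3-yl in place of pyridin-4-yl on an amide-type nitrogen. Among the compounds with values here, no pair of measured compounds differs in one place only, so there is no measured step to lean on for a change of this kind; the only guide is that compound 2 and compound 1, which differ in more than one place, give numbers within the scatter of each other. A step from compound 2 to compound 4 of a number 4 percentage points higher from compound 2 to compound 4 (within the scatter) is expected, not beyond the scatter. Compound 4 is therefore expected to give about 36% in this assay, within a range from 18% to 62%.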

Compound 4, a percentage reported as activity, at one concentration (the size of the read-out at that concentration, not a potency): 111%
For compound 4 the middle estimate is 75 percentage points below the measured one, outside the stated range (above it).
By their numbers in this assay, from the lowest: compounds 1 and 2 (each within the scatter of the next); then compound 3; then compound 4.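

In this assay the swap of pyridin-4-yl for pyridin-3-yl on an amide-type nitrogen gives a number 79 percentage points higher from compound 2 to compound 4 (beyond the scatter) even though the heavy atoms, ring type and counted hydrogen-bond donors and acceptors stay the same. Within the data shown here, this is the only step here between compounds that differ in one place, and it shows that this position is highly sensitive to which pyridinyl group it carries. Nothing shown accounts for the size of this step.

As far as these compounds go, whether pyridin-2-yl or a plain phenyl on the same nitrogen would behave like pyridin-4-yl or like pyridin-3-yl remains open. This single pair also cannot show whether the same swap would matter as much with a longer chain.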